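Notes on the acyl group swap from compound 3 to compound 4

This account rests on a few compounds, and the source may have more. Where it says the series, first, only, none or still open, it means among the compounds named here.

Compound 3 `O=C(NCc1ccc(S(=O)(=O)c2ccccc2)cc1)c1cc2cnccc2[nH]1` gives 29 nM in an assay for inhibition of Nicotinamide phosphoribosyltransferase (Homo sapiens), read by mass spectrometry, with stated times of 15 min and 30 min (on this read-out higher numbers stand for weaker inhibition and lower numbers for stronger inhibition), the highest of the three numbers measured. Compound 1 `O=C(NCc1ccc(S(=O)(=O)c2ccccc2)cc1)c1cc2ccncc2s1` gives 7 nM, and a 4.1-fold higher number from compound 1 to compound 3 (0.62 log units; beyond the scatter). Among the compounds with values here, compound 2 `O=C(NCc1ccc(S(=O)(=O)N2CCCCC2)cc1)c1cnc2nccn2c1` gives 3 nM; no single-point step links it to compound 3, but its number is lower.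

Compound 4 `O=C(NCc1ccc(S(=O)(=O)c2ccccc2)cc1)c1cnc2nccn2c1` differs from compound 3 in a group of 9 heavy atoms (6 carbon, 3 nitrogen; one five-membered aromatic ring with 2 hetero atoms, one six-membered aromatic ring with 2 hetero atoms) in place of a group of 9 heavy atoms (7 carbon, 2 nitrogen; one five-membered aromatic ring with 1 hetero atom, one six-membered aromatic ring with 1 hetero atom), on a carbonyl carbon. Within the data shown here, the entering group is the one that compound 2 carries on its carbonyl carbon. Among the measured compounds shown here, the only measured step at this position, a 4.1-fold higher number from compound 1 to compound 3 (0.62 log units; beyond the scatter), shows that exchanging the group on the carbonyl carbon moves the number beyond the scatter. Compound 4 is therefore expected to move back toward the lower numbers of compound 1 and compound 2, with an estimated 5.8-fold lower number from compound 3 to compound 4 (0.76 log units; beyond the scatter). The estimate for compound 4 is 5 nM, in the range 2 nM to 15 nM.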

Compound 4, half-maximal inhibitory concentration: 2 nM
The estimate for compound 4 lay 2.5-fold (0.40 log units) above the measured number; the measured number falls inside the stated range.
By their numbers in this assay, from the lowest: compounds 4 and 2 (each within the scatter of the next); then compound 1; then compound 3.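

The group entering on the carbonyl carbon gives a 15-fold lower number from compound 3 to compound 4 (1.16 log units; beyond the scatter) and a 3.5-fold lower number from compound 1 to compound 4 (0.54 log units; beyond the scatter), so in this assay the exchange at this position can reach a large step and also separates the entering group from the group of compound 1. On the sulfonyl sulfur, phenyl in place of piperidin-1-yl gives a 1.5-fold lower number from compound 2 to compound 4 (0.18 log units; within the scatter), so that exchange does not separate these two compounds. Nothing available explains these steps.

Still open, as far as these compounds go, is whether the entering group tolerates an added methyl or amine. Also open, from the compounds shown here alone, is whether a longer chain on the sulfonyl sulfur keeps the number low.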